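The compounds below may be only part of what the source reports. "The series", "measured", "known", "first", "only" and "open" are said of these compounds alone.

Working notes on a series built on one shared core. Among the measured compounds shown here, compound 1 `N#Cc1ccc(-c2nc(C(c3ccc(F)cc3)c3ccc(F)cc3)sc2CC(=O)O)cc1` and compound 2 `O=C(O)Cc1sc(C(Cc2ccccc2)c2ccccc2)nc1-c1ccc(Cl)cc1` are the two compounds measured so far. In an in vitro functional assay on HEK285-7 cells for antagonist activity at prostaglandin D2 receptor 2 (Homo sapiens), read by BRET and beta-arrestin recruitment (a higher number here means a larger maximal response, a lower number a smaller maximal response), compound 1 gives 30%, the lowest of the two numbers at hand; compound 2 gives 50%, a number higher by a margin beyond the usual scatter. Compound 3 `O=C(O)Cc1sc(C(c2ccc(F)cc2)c2ccc(F)cc2)nc1-c1ccco1` has not been measured. It differs from compound 1 in one place on the core: furan-2-yl in place of 4-cyanophenyl on an aromatic carbon. No pair of measured compounds that differ in only one place is available, so the size of this change in this assay can only be judged from the two numbers shown. A modest rise is expected, one that may still sit within the scatter: the step of a number 10 percentage points higher from compound 1 to compound 3 (within the scatter) is the estimate. For compound 3 the expected value in this assay is 40%, with a range from 15% to 65%.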

Compound 3, largest response reached (reported as efficacy), in percent of the reference or control that the assay uses: 80%
For compound 3 the middle estimate is 40 percentage points below the measured one; measured number above the stated range.
By their numbers in this assay, from the lowest: compound 1; then compound 2; then compound 3.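

Among the compounds shown here, at the aromatic carbon next to the ring nitrogen and next to the ring atom that bears a carboxymethyl group, the substituent clearly matters in this assay: furan-2-yl in place of 4-cyanophenyl gives a number 50 percentage points higher from compound 1 to compound 3 (beyond the scatter), the first single-place step. The two groups have the same hydrogen-bond counts, 0 donors and 1 acceptor, so those counts do not separate them, whereas ring size, heavy-atom count and the presence of the nitrile all change together. Nothing at hand explains the size of this step.

Which of these differences goes with the step remains open. A plain phenyl or a thiophen-2-yl at this carbon would help to separate ring size from the loss of the nitrile.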